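The compounds below may be only part of what the source reports. "The series", "measured", "known", "first", "only" and "open" are said of these compounds alone.

Of the compounds shown here, three have so far been tested in an ADME assay on HEK293 cells (Homo sapiens) for cytotoxicity, read by MTT assay, with a stated time of 72 h; a lower number here means a stronger inhibitor, a higher number a weaker inhibitor. Compound 1 `O=C(CN1CCN(C(=O)c2ccc(Cl)cc2)CC1)N1CCN(CCCc2c[nH]c3ccccc23)CC1` gives 98200 nM in this assay. Compound 2 `COc1ccc(C(=O)N2CCN(CC(=O)N3CCN(CCCc4c[nH]c5ccccc45)CC3)CC2)cc1` differs from compound 1 by methoxy in place of chloro on an aromatic carbon, and in this assay compound 2 gives 156000 nM; the step is a 1.6-fold higher number from compound 1 to compound 2 (0.20 log units; within the scatter). Compound 3 `O=C(CN1CCN(C(=O)c2cccc(Cl)c2)CC1)N1CCN(CCCc2c[nH]c3ccccc23)CC1` has a differently built core, the difference being (3-chlorophenyl in place of 4-chlorophenyl on a carbonyl carbon). In this assay compound 3 gives 99100 nM, and a 1.0-fold higher number from compound 1 to compound 3 (0.00 log units; within the scatter) shows how close the two cores lie.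

Compound 4 `COc1cccc(C(=O)N2CCN(CC(=O)N3CCN(CCCc4c[nH]c5ccccc45)CC3)CC2)c1` is not yet measured. It stands to compound 3 as compound 2 stands to compound 1, the difference being (methoxy in place of chloro on an aromatic carbon). This is the same kind of change, not the same one: in compound 2 the methoxy sits para to a large group, while in compound 4 it sits meta to a large group. The earlier step of a 1.6-fold higher number from compound 1 to compound 2 (0.20 log units; within the scatter) stayed within the scatter. Compound 4 is therefore expected to move by about the same amount, a 1.3-fold higher number from compound 3 to compound 4 (0.12 log units; within the scatter). Compound 4 is estimated at 130000 nM, with a likely range from 60000 nM to 260000 nM.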

Compound 4, half-maximal inhibitory concentration: 143000 nM
Compound 4: the middle estimate sits 1.1-fold (0.04 log units) below what was measured; the measured number falls inside the stated range.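

In this assay, the change from chloro to methoxy looks the same when carried from the core of compound 1 to the core of compound 3: the same change on two cores in this assay, a 1.6-fold higher number (0.20 log units; within the scatter) from compound 1 to compound 2 and a 1.4-fold higher number (0.16 log units; within the scatter) from compound 3 to compound 4, 1.1-fold (0.04 log units) apart, within the scatter of two such steps. The other steps tell the same story: the new step is a 1.4-fold higher number from compound 3 to compound 4 (0.16 log units; within the scatter), moving the methoxy gives a 1.1-fold lower number from compound 2 to compound 4 (0.04 log units; within the scatter), and exchanging the whole substituted phenyl gives a 1.5-fold higher number from compound 1 to compound 4 (0.16 log units; within the scatter), so these four compounds cannot be told apart in this measurement. This agreement does not show that the change has a real effect that transfers between cores, since each step is too small to separate from repeat-to-repeat variation, and two pairs cannot establish a rule for the series.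

Going by these compounds, it remains open whether an amine, a carboxylic acid or a longer alkoxy chain in place of the chloro on that aromatic ring would produce a step beyond the scatter. Whether the two cores would also match outside this assay is equally unknown.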